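The source may hold more compounds than are shown below. What is called first, only, known or untested is meant among the compounds shown, and "the series" means these compounds.

Measured compounds:
compound 1, `O=c1c(OCc2ccccc2[N+](=O)[O-])c(-c2ccccc2)oc2cc(O)cc(O)c12`: in an ADME assay on Huh-5-2 cells (Homo sapiens) for cytotoxicity, read by WST assay, with a stated time of 3 days (on this read-out higher numbers stand for lower toxicity in this test and lower numbers for higher toxicity in this test), compound 1 gives 51000 nM
compound 2, `COc1ccccc1COc1c(-c2ccccc2)oc2cc(O)cc(O)c2c1=O`: in this assay compound 2 gives 53000 nM

Going by the values given here, compound 2 holds the higher of the two numbers, yet its only neighbour is compound 1, and the step of a 1.0-fold higher number from compound 1 to compound 2 (0.02 log units; within the scatter) places the two at the same level. On the numbers shown, then, compound 2 stands nowhere apart from compound 1.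

Compound 3, `O=c1c(OCc2cccc([N+](=O)[O-])c2)c(-c2ccccc2)oc2cc(O)cc(O)c12`, is not yet measured. It differs from compound 2 by 3-nitrophenyl in place of 2-methoxyphenyl on a saturated chain carbon bound to an oxygen on an aromatic ring. Among the compounds with values here, the one measured step that bears on it, a 1.0-fold higher number from compound 1 to compound 2 (0.02 log units; within the scatter), exchanges a nitro group for a methoxy group on the ring that hangs from the same chain carbon, and that exchange left the number unchanged. Within the data shown here, no measured pair shows a nitro group carried on a different ring carbon, so that part of the change is untested. Among the measured compounds shown here, with both measured compounds at one level and the only relevant step flat, the expected step of a 1.0-fold lower number from compound 2 to compound 3 (0.01 log units; within the scatter) is none beyond the scatter. Compound 3 is therefore estimated at 52000 nM in this assay, with a range from 25000 nM to 105000 nM.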

Compound 3, half-maximal cytotoxic concentration: 31000 nM
The estimate for compound 3 lay 1.7-fold (0.22 log units) above the measured number; measured number inside the range.
By their numbers in this assay, from the lowest: compounds 3, 1 and 2 (each within the scatter of the next).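

In this assay, going by these compounds alone, the step of a 1.6-fold lower number from compound 1 to compound 3 (0.22 log units; within the scatter) is the first measured test of which ring carbon carries the nitro group on the ring attached to the saturated chain carbon, and this step lies within the scatter. The step of a 1.7-fold lower number from compound 2 to compound 3 (0.23 log units; within the scatter) puts 3-nitrophenyl in place of 2-methoxyphenyl at the same place and also lies within the scatter, so it joins the earlier exchange of nitro for methoxy in showing no separation. All three compounds therefore stand at one level in this test, whichever of these two groups the ring carries and whichever of these two ring carbons holds the nitro group, and no measurement shown offers an explanation for this.

The compounds shown carry only a nitro or a methoxy group on this ring, so they leave open whether an amine or a carboxylic acid there would give a number away from this level. They also leave open whether a longer chain between the ring and the oxygen would keep the number at this level, and how a methoxy group on another ring carbon would read.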